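The source may hold more compounds than are shown below. What is called first, only, known or untested is meant among the compounds shown, and "the series" means these compounds.

Measured in a functional assay on Jurkat cells for inhibition of nuclear factor NF-kappa-B complex (Homo sapiens); on this read-out higher numbers stand for weaker inhibition and lower numbers for stronger inhibition:
- compound 1 `CCOC(=O)c1cnc(-c2ccc(OC)cc2)nc1NN1C(=O)C=C(C)C1=O` gives 900 nM
- compound 2 `CCOC(=O)c1cnc(-c2cccc(OC)c2)nc1NN1C(=O)C=C(C)C1=O` gives 5000 nM
- compound 3 `CCOC(=O)c1cnc(-c2cccc([N+](=O)[O-])c2)nc1NN1C(=O)C=C(C)C1=O` gives 7000 nM

Compound 3 carries the highest of the three numbers. Compound 2 sits within the scatter of it, as a 1.4-fold higher number from compound 2 to compound 3 (0.15 log units; within the scatter) shows, while compound 1 is clearly lower, with a 7.8-fold higher number from compound 1 to compound 3 (0.89 log units; beyond the scatter) and a 5.6-fold higher number from compound 1 to compound 2 (0.74 log units; beyond the scatter) marking the two larger steps.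

Compound 4 `CCOC(=O)c1cnc(Sc2ccccc2)nc1NN1C(=O)C=C(C)C1=O` changes the ring attached to the core: phenylsulfanyl in place of 3-nitrophenyl on an aromatic carbon. Going by the values given here, none of the measured steps exchanges that ring for a sulfur-linked one; each only moves or swaps a substituent on it, so they bear on this change only loosely. The estimate is therefore that a 1.8-fold lower number from compound 3 to compound 4 (0.24 log units; within the scatter) stays modest, in either direction. Compound 4 is expected to give about 4000 nM in this assay, in a range from 800 nM to 20000 nM.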

Compound 4, half-maximal inhibitory concentration: 1000 nM
Estimate against measurement, compound 4: 4.0-fold (0.60 log units) above; measured number inside the range.
By their numbers in this assay, from the lowest: compounds 1 and 4 (each within the scatter of the next); then compounds 2 and 3 (each within the scatter of the next).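

At this position of the shared core, a ring linked through sulfur can sit level with the 4-methoxyphenyl ring (a 1.1-fold higher number from compound 1 to compound 4 (0.05 log units; within the scatter)). Against the other two rings, phenylsulfanyl gives clearly lower numbers (a 5.0-fold lower number from compound 2 to compound 4 (0.70 log units; beyond the scatter); a 7.0-fold lower number from compound 3 to compound 4 (0.85 log units; beyond the scatter)), so stronger inhibition in this assay does not require a directly attached ring or a substituent on it. Nothing available explains these differences.

Still open, from the compounds shown here alone, is whether a link through oxygen or an amine nitrogen would serve as well as sulfur, and whether a methoxy group on the phenylsulfanyl ring would shift the number.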